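Replacing the ring on the amide nitrogen with an open chain

The source may hold more compounds than are shown below. What is called first, only, known or untested is meant among the compounds shown, and "the series" means these compounds.

Measured so far:
compound 1, `COc1cc(C(=O)NC2CCN(C)CC2)ccc1Nc1ncc2c(n1)N(C1CCCC1)[C@H](C)C(=O)N2C` — in an assay on isolated protein for inhibition of serine/threonine-protein kinase PLK1 (Homo sapiens), read by Z'-LYTE (a higher number here means a weaker inhibitor, a lower number a stronger inhibitor), compound 1 gives 1.1 nM
compound 2, `COc1cc(C(=O)NC2CCCCC2)ccc1Nc1ncc2c(n1)N(C1CCCC1)[C@H](C)C(=O)N2C` — in this assay compound 2 gives 160 nM
compound 3, `COc1cc(C(=O)NC2=CCN(C)C=C2)ccc1Nc1ncc2c(n1)N(C1CCCC1)[C@H](C)C(=O)N2C` — in this assay compound 3 gives 8.4 nM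

Compound 3 stands second highest of the three numbers in this assay: compound 1 lies below it by a 7.6-fold higher number from compound 1 to compound 3 (0.88 log units; beyond the scatter), while compound 2 lies above it by a 19-fold lower number from compound 2 to compound 3 (1.28 log units; beyond the scatter). All three share one core and differ only in the group on the amide nitrogen.

Compound 4, `COc1cc(C(=O)NCCN(C)C)ccc1Nc1ncc2c(n1)N(C1CCCC1)[C@H](C)C(=O)N2C`, carries the change (a group of 5 heavy atoms (4 carbon, 1 nitrogen; no ring) in place of a group of 7 heavy atoms (6 carbon, 1 nitrogen; one six-membered non-aromatic ring with 1 hetero atom), on an amide-type nitrogen). Among the measured compounds shown here, two measured steps bear on this. Replacing the nitrogen-containing ring of compound 1 with a ring of carbon only gave a 150-fold higher number from compound 1 to compound 2 (2.16 log units; beyond the scatter); restoring a nitrogen-containing ring in compound 3 gave a 19-fold lower number from compound 2 to compound 3 (1.28 log units; beyond the scatter). Both groups that contain a nitrogen sit far below the cyclohexyl compound, and the incoming 2-(dimethylamino)ethyl chain also contains a nitrogen. A modest step downward in this assay is therefore expected for compound 4, estimated as a 2.8-fold lower number from compound 3 to compound 4 (0.45 log units; beyond the scatter), roughly toward compound 1. Compound 4 is expected to give about 3 nM, within a range of 0.8 nM to 12 nM.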

Compound 4, half-maximal inhibitory concentration: 21 nM
The estimate for compound 4 lay 7.0-fold (0.85 log units) below the measured number; measured number outside the range, above it.
By their numbers in this assay, from the lowest: compound 1; then compound 3; then compound 4; then compound 2.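

In this assay the open chain falls short of both nitrogen-containing ring groups, with a 19-fold higher number from compound 1 to compound 4 (1.28 log units; beyond the scatter) and also a 2.5-fold higher number from compound 3 to compound 4 (0.40 log units; beyond the scatter) in this comparison, so having a nitrogen in the group does not by itself set the number. The chain still keeps much of the gain over the all-carbon ring, with a 7.6-fold lower number from compound 2 to compound 4 (0.88 log units; beyond the scatter) at this amide-type nitrogen, and among these four compounds every nitrogen-containing group gives a lower number than cyclohexyl, with none going against that. Nothing measured here explains why the ring and the chain differ.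

The compounds shown leave open whether the size of the step depends on the ring itself or on the length of the chain, which a 3-(dimethylamino)propyl chain would help to test. They also leave open whether the methyl on the nitrogen matters, as a piperidin-4-yl ring without it or a 2-aminoethyl chain would show.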